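Trading methyl for fluoro on a weak inhibitor

A few compounds are considered here, and "the series" means these few. Any claim that something is new, unique, unknown or untested is made for them only; others in the source may bear on it.

Among the measured compounds shown here, in a functional assay on the whole organism for inhibition, with Echinochloa esculenta as the target (a lower number here means a stronger inhibitor, a higher number a weaker inhibitor), compound 3 (`Cc1cc(Cl)ccc1-n1c(=S)n2n(c1=S)CCCC2`) gives 2240 nM, the highest of the three numbers measured so far. Compound 2 (`S=c1n(-c2ccc(Cl)cc2)c(=S)n2n1CCCC2`) gives 89.1 nM, and compound 1 (`CC(C)Oc1cc(-n2c(=S)n3n(c2=S)CCCC3)c(F)cc1Cl`) gives 12.3 nM. Compound 4 (`Fc1cc(Cl)ccc1-n1c(=S)n2n(c1=S)CCCC2`) is still unmeasured. It has fluoro in place of methyl on an aromatic carbon, ortho to a large group and meta to a chloro group: fluoro in place of methyl on an aromatic carbon. For the measured compounds named here, one measured step bears directly on this change: a 25-fold higher number from compound 2 to compound 3 (1.40 log units; beyond the scatter), a large step that arose when methyl replaced hydrogen at that same place. Compound 1, at 12.3 nM, also carries fluoro there, but it differs from compound 2 elsewhere too, so it offers only loose support. Going by the values given here, no measured pair isolates fluoro. Removing the methyl is therefore expected to give a large move towards a lower number in this assay, recovering most of that step. The estimated change is a 15-fold lower number from compound 3 to compound 4 (1.17 log units; beyond the scatter). For compound 4 the expected value is 150 nM, with an estimated range of 30 nM to 800 nM.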

Compound 4, half-maximal inhibitory concentration: 91.2 nM
For compound 4 the middle estimate is 1.6-fold (0.22 log units) above the measured one, and the stated range covers the measured number.
By their numbers in this assay, from the lowest: compound 1; then compounds 2 and 4 (each within the scatter of the next); then compound 3.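

Fluoro at this place removes the whole cost of the methyl in this assay, with a 25-fold lower number from compound 3 to compound 4 (1.39 log units; beyond the scatter) as the step back, and a 1.0-fold higher number from compound 2 to compound 4 (0.01 log units; within the scatter) shows that fluoro and hydrogen cannot be told apart here, so among compounds 2, 3 and 4 only methyl stands out. With fluoro held constant, a 7.4-fold higher number from compound 1 to compound 4 (0.87 log units; beyond the scatter) isolates the isopropoxy group, so the stronger number of compound 1 cannot be credited to its fluoro. Nothing available explains why methyl differs from fluoro and hydrogen at this place.

From the compounds shown here alone, whether ethyl, methoxy or chloro at this place would behave like methyl or like fluoro stays open. So does whether the isopropoxy group would bring the same change in a compound carrying hydrogen or methyl instead of fluoro.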